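Bromo in Place of Hydrogen: an Expectation for Compound 3

A few compounds are considered here, and "the series" means these few. Any claim that something is new, unique, unknown or untested is made for them only; others in the source may bear on it.

In a functional assay (strain AB) with Danio rerio as the target, read by microscopy, with a stated time of 1 h (on this read-out lower numbers stand for an effect already at smaller amounts and higher numbers for an effect only at larger amounts of compound), compound 1 `CCN1CCc2c(sc(NC(=O)Nc3ccccc3)c2C(N)=O)C1` gives > 25000 nM, which is a limit of the assay and not a number. That boundary is the limit of > 25000 nM in this assay, at which 1 of the 2 values shown sits. Compound 2 `CC(C)(C)OC(=O)CCCC[N+]1(C)CCc2c(sc(NC(=O)Nc3ccc(Cl)cc3)c2C(N)=O)C1` gives 140 nM in this assay — compound 2 stands at 140 nM. Compound 3 `CCN1CCc2c(sc(NC(=O)Nc3ccc(Br)cc3)c2C(N)=O)C1` differs from compound 1 by bromo in place of hydrogen on an aromatic carbon. For the measured compounds named here, no measured pair covers this change alone, so the expected step of an at least 2.0-fold lower number from compound 1 to compound 3 (0.31 log units; beyond the scatter) is set as a modest move toward an effect at smaller amounts. Compound 3 is estimated at 12000 nM, expected to fall between 2000 nM and 25000 nM.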

Compound 3, half-maximal effective concentration: 3130 nM
Estimate against measurement, compound 3: 3.8-fold (0.58 log units) above, within the range that was stated.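

In this assay, the change from phenyl to 4-bromophenyl alone gives an at least 7.9-fold lower number from compound 1 to compound 3 (0.90 log units; beyond the scatter), so a single bromo at this place on the ring is enough to bring a measured value. For compound 1, > 25000 nM is a limit of the assay and not a number. The true size of the step therefore stays unknown, because compound 1 sits at an assay boundary: the limit of > 25000 nM in this assay, at which 1 of the 3 values shown sits.

The compounds shown leave open whether chloro, methoxy or a nitrile at this place would give a similar step. They also leave open whether bromo would act alike elsewhere on this ring.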